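The source may hold more compounds than are shown below. What is called first, only, known or untested is meant among the compounds shown, and "the series" means these compounds.

Compound 1, with the structure `Cc1cc(F)ccc1C1=Nc2c(Cl)cccc2SC(C(=O)O)C1`, carries a chloro group on the core, and it was tested in a functional assay on HL-60 cells (Homo sapiens), read by MTT assay, with a stated time of 72 h; a lower number here means a stronger inhibitor of growth, a higher number a weaker inhibitor of growth. In this assay compound 1 gives > 10000000 nM, which is a limit of the assay rather than a measured number. A related compound, compound 2, with the structure `Cc1cc(F)ccc1C1=Nc2ccc(Cl)cc2SC(C(=O)O)C1`, carries its chloro group at a different place on the same core. In this assay compound 2 likewise gives > 10000000 nM, again a limit and not a number. So compound 1 stands at the limit of > 10000000 nM in this assay, at which 2 of the 2 values shown sit, and nothing among the values shown sets it apart from compound 2.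

Compound 3, with the structure `Cc1cc(F)ccc1C1=Nc2c(Br)cccc2SC(C(=O)O)C1`, differs from compound 1 by bromo in place of chloro on an aromatic carbon. Among the measured compounds shown here, no step between two measured compounds is available to show how much a change of this kind moves the result. With both measured compounds sitting at the limit, the step from compound 1 to compound 3 is expected to be a number no higher from compound 1 to compound 3 (the limit leaves the size open), which means nothing beyond the usual scatter. For compound 3 the expected result in this assay is therefore 10000000 nM, within a range from 2000000 nM to 10000000 nM, most likely reported again only as a limit.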

Compound 3, concentration for 50% growth inhibition: 2500000 nM
Beside the measured number, compound 3's estimate is 4.0-fold (0.60 log units) above it, and the stated range covers the measured number.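

The swap of chloro for bromo on this aromatic carbon gives an at least 4.0-fold lower number from compound 1 to compound 3 (0.60 log units; beyond the scatter) in this assay, so the position responds to a change of a single atom, something the two earlier compounds could not show. The value of compound 1 is a limit, which makes this step a minimum and leaves its true size open. Compound 3 is the only compound shown that carries a number rather than a limit, and it stands apart from the other two: the limit of > 10000000 nM in this assay, at which 2 of the 3 values shown sit.

The compounds shown do not tell whether the result follows from some property of bromo or whether other groups on this carbon, such as iodo, methyl, methoxy or an amine, would give a lower or a higher number in this assay. As far as these compounds go, it also remains open whether bromo would have a similar effect at the place where compound 2 carries its chloro group, and whether an amide in place of the carboxylic acid would change the result.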